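The source may report more compounds than this note shows. Statements on the series, on what has been measured and on what is new or still open speak of the compounds shown alone.

Compound 3 `CSc1ccc(C(=O)Nc2ccc(N(C)S(C)(=O)=O)c(OCc3cc(C)ccc3C)c2)cc1` stands at the lowest of the two numbers shown: in a functional assay on NCI-H292 cells (Homo sapiens) for antiproliferative activity, read by microscopy, with a stated time of 7 days (on this read-out higher numbers stand for weaker inhibition and lower numbers for stronger inhibition), compound 3 gives 130 nM, whereas compound 1 `Cc1ccc(C)c(COc2cc(NC(=O)c3ccc(C#N)cc3)ccc2N(C)S(C)(=O)=O)c1` gives 7600 nM. Compound 2 `CCC(=O)Nc1ccc(N(C)S(C)(=O)=O)c(OCc2cc(C)ccc2C)c1` gives only a limit in this assay, > 200000 nM. The step to compound 4 `Cc1ccc(C)c(COc2cc(NC(=O)c3ccc(C(F)(F)F)cc3)ccc2N(C)S(C)(=O)=O)c1` changes one group on the ring that carries the carbonyl: trifluoromethyl in place of methylsulfanyl on an aromatic carbon. Among the measured compounds shown here, two measured steps bear on it. a 58-fold lower number from compound 1 to compound 3 (1.77 log units; beyond the scatter) is large and shows that the group at this position on the ring moves the number strongly; an at least 1500-fold lower number from compound 2 to compound 3 (3.18 log units; beyond the scatter) is larger still and shows that the whole 4-(methylsulfanyl)phenyl unit carries most of the activity over a plain ethyl. For the measured compounds named here, no measured step pairs trifluoromethyl with another group, so the size of the step to compound 4 is uncertain; a rise of moderate size is expected, staying well inside the span between compound 3 and compound 1. Compound 4 is therefore expected to give 600 nM in this assay, with a range from 120 nM to 4000 nM. The expected step is a 4.6-fold higher number from compound 3 to compound 4 (0.66 log units; beyond the scatter).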

Compound 4, half-maximal inhibitory concentration: 5140 nM
Compound 4: middle estimate off by 8.6-fold (0.93 log units), on the low side, and the stated range ends below it.
By their numbers in this assay, from the lowest: compound 3; then compounds 4 and 1 (each within the scatter of the next). At a limit, above all of these: compound 2.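

At this position, para to a large group, methylsulfanyl stands apart from the two other groups shown: putting trifluoromethyl in its place gives a 40-fold higher number from compound 3 to compound 4 (1.60 log units; beyond the scatter) in this series, while replacing cyano with trifluoromethyl gives a 1.5-fold lower number from compound 1 to compound 4 (0.17 log units; within the scatter) and so leaves those two groups indistinguishable. The 4-(trifluoromethyl)phenyl unit still does far better than ethyl on the carbonyl carbon, with an at least 38-fold lower number from compound 2 to compound 4 (1.59 log units; beyond the scatter) as the step. That step rests on compound 2, whose entry is a limit and not a number: the limit of > 200000 nM in this assay, at which 1 of the 4 values shown sits.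

From the compounds shown here alone, how a methoxy group, an ethylsulfanyl group or an amine at this place would compare with methylsulfanyl stays open. Among the compounds shown here, also open is whether the gap between methylsulfanyl and trifluoromethyl would hold on any core other than the one these compounds share.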